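Swapping the Ether Chain for a Carbamate on the Core

The source may report more compounds than this note shows. Statements on the series, on what has been measured and on what is new or still open speak of the compounds shown alone.

Of the compounds shown here, two of a shared core have been tested so far. Compound 1 `CC(C)=CCC/C(C)=C/COc1cc(=O)n(CCCO)c2c1CC(CC=C(C)C)C(C)(C)C2` gives 18.4% in a functional assay on PANC-1 cells (Homo sapiens) for inhibition, read by MTT assay, with a stated time of 24 h, tested at 10 uM; on this read-out higher numbers stand for more inhibition at the one concentration tested (going by the name of the read-out) and lower numbers for less inhibition. Within the data shown here, compound 2 `CC(C)=CCC1Cc2c(OCCCNC(=O)c3cccs3)cc(=O)n(CCCO)c2CC1(C)C` gives 5.6% in this assay, the lowest of the two numbers; its nearest neighbour is compound 1, and the only measured step, a number 12.8 percentage points lower from compound 1 to compound 2 (beyond the scatter), shows that exchanging the chain on the oxygen on the aromatic ring lowered the read-out modestly.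

Compound 3 `COc1ccccc1NC(=O)Oc1cc(=O)n(CCCO)c2c1CC(CC=C(C)C)C(C)(C)C2` has not been measured. It differs from compound 2 in one place: (2-methoxyphenyl)carbamoyl in place of 3-(((thiophen-2-yl)carbonyl)amino)propyl on an oxygen on an aromatic ring. Among the measured compounds shown here, no measured step covers this particular exchange; the step from compound 1 to compound 2 only shows that altering the group on this oxygen can move the read-out by a modest amount, in that case downward. For the measured compounds named here, with both measured numbers low, and no step pointing clearly in either direction, the expected step of a number 6.4 percentage points higher from compound 2 to compound 3 (within the scatter) is small and not beyond the scatter. Compound 3 is therefore estimated to give 12% in this assay, within a range from -2% to 28%.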

Compound 3, a percentage reported as inhibition, at one concentration (the size of the read-out at that concentration, not a potency): 0%
Beside the measured number, compound 3's estimate is 12 percentage points above it, and the stated range covers the measured number.
By their numbers in this assay, from the lowest: compounds 3 and 2 (each within the scatter of the next); then compound 1.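

In this assay, the step of a number 5.6 percentage points lower from compound 2 to compound 3 (within the scatter) shows that a carbamate-linked (2-methoxyphenyl)carbamoyl group on this oxygen cannot be told apart from the 3-(((thiophen-2-yl)carbonyl)amino)propyl group, although one carries a six-membered aromatic ring of carbon only and the other a five-membered aromatic ring with a hetero atom. The second comparison is clearer, with the step of a number 18.4 percentage points lower from compound 1 to compound 3 (beyond the scatter), which means that two quite different replacements for the 3,7-dimethylocta-2,6-dien-1-yl chain of compound 1 now both sit beyond the scatter from it, and compound 1 is the only one of the three that stands apart. No measurement on hand offers an explanation for this drop, or for the lack of separation between compound 2 and compound 3.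

From the compounds shown here alone, what remains open is whether the long hydrocarbon chain itself matters on this oxygen, or whether a shorter chain, a plain methyl group or a chain ending in an amine or a carboxylic acid would match or pass compound 1 at 18.4%. The three compounds also leave open how any of these groups would behave at other concentrations, since a single-concentration read-out gives no potency.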